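The source may report more compounds than this note shows. Statements on the series, on what has been measured and on what is new or still open speak of the compounds shown alone.

Of the compounds shown here, three have so far been measured in a functional assay on cells (Leukemia cell, Homo sapiens) for cytotoxicity, read by sulforhodamine B assay, with a stated time of 48 h; a higher number here means a weaker inhibitor of growth, a lower number a stronger inhibitor of growth. Compound 1 `COc1ccc(OC)c(-c2cc(-c3ccccc3)nn2-c2ccc(S(N)(=O)=O)cc2)c1` gives 68500 nM. Compound 2 `Oc1ccc(O)c(-c2cc(-c3ccccc3)nn2-c2ccccc2)c1` gives 100000 nM, the highest of the three numbers, although its gaps to the other two stay within the usual scatter. Compound 3 `Oc1ccc(O)c(-c2cc(-c3ccc(Cl)cc3)nn2-c2ccccc2)c1` gives 49700 nM. Going by the values given here, the only step between compounds that differ in one place, a 2.0-fold lower number from compound 2 to compound 3 (0.30 log units; within the scatter), also stays within the scatter and so shows no change that can be trusted.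

Compound 4 `NS(=O)(=O)c1ccc(-n2nc(-c3ccccc3)cc2-c2cc(O)ccc2O)cc1` has not yet been measured. It differs from compound 2 in one place: sulfamoyl in place of hydrogen on an aromatic carbon. Among the compounds with values here, no measured pair shows this change on its own. Compound 1 carries the same sulfamoyl group, but it differs from compound 2 at two further places, so the values of compound 1 and compound 2 only show that the two numbers lie within the scatter of each other. Nothing measured points to a step beyond the scatter. Compound 4 is therefore expected to give about 75000 nM, within a range of 35000 nM to 160000 nM. The expected step of a 1.3-fold lower number from compound 2 to compound 4 (0.12 log units; within the scatter) is estimated to stay within the scatter.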

Compound 4, concentration for total growth inhibition: 100000 nM
The estimate for compound 4 lay 1.3-fold (0.12 log units) below the measured number; low and high end bracket the measured number.
By their numbers in this assay, from the lowest: compounds 3, 1, 2 and 4 (each within the scatter of the next).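

In this assay, sulfamoyl in place of hydrogen, on an aromatic carbon para to a large group, now has a reading of its own: the exchange gives no change at the digits printed from compound 2 to compound 4 (within the scatter) and so shows no change that can be trusted. Going by these compounds alone, compound 4 also gives the first one-place reading of a second change, since 2,5-dihydroxyphenyl in place of 2,5-dimethoxyphenyl gives a 1.5-fold higher number from compound 1 to compound 4 (0.16 log units; within the scatter) and this step also shows no trustworthy change. No separate measurement is available that bears on these two results.

On these data alone, whether an amine or a carboxylic acid at this same place would give a step beyond the scatter remains open. Also open, as far as these compounds go, is whether sulfamoyl would give the same reading on a core carrying the chloro group of compound 3.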